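A few compounds are considered here, and "the series" means these few. Any claim that something is new, unique, unknown or untested is made for them only; others in the source may bear on it.

Measured so far in an assay for inhibition of Nicotinamide phosphoribosyltransferase (Homo sapiens), read by mass spectrometry, with stated times of 15 min and 30 min; a higher number here means a weaker inhibitor, a lower number a stronger inhibitor:
compound 1 `O=C(NCc1ccc(S(=O)(=O)N2CCCCC2)cc1)c1cc2cnccc2s1`: 150 nM
compound 2 `O=C(NCc1ccc(S(=O)(=O)N2CCCCC2)cc1)c1cnc2nccn2c1`: 3 nM

Within the data shown here, compound 2 holds the lower of the two numbers in this assay; the single measured step, a 50-fold lower number from compound 1 to compound 2 (1.70 log units; beyond the scatter), is large and concerns the group on the carbonyl carbon only. Compound 3 `O=C(NCc1ccc(S(=O)(=O)c2cccc(C(F)(F)F)c2)cc1)c1cnc2nccn2c1` changes the other end: 3-(trifluoromethyl)phenyl in place of piperidin-1-yl on a sulfonyl sulfur. Among the measured compounds shown here, no measured pair varies the group on the sulfonyl sulfur, so nothing in the data speaks directly to this change. The step of a 1.7-fold higher number from compound 2 to compound 3 (0.22 log units; within the scatter) is therefore expected to stay small, within the scatter, and compound 3 is estimated at 5 nM, with a range from 1.5 nM to 20 nM.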

Compound 3, half-maximal inhibitory concentration: 1 nM
Compound 3: middle estimate off by 5.0-fold (0.70 log units), on the high side; the measured number lies below the stated range.
By their numbers in this assay, from the lowest: compound 3; then compound 2; then compound 1.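

The group on the sulfonyl sulfur can be changed without loss in this assay: with the rest of compound 2 held, 3-(trifluoromethyl)phenyl in place of piperidin-1-yl gives a 3.0-fold lower number from compound 2 to compound 3 (0.48 log units; beyond the scatter) and a modest gain. The piperidin-1-yl nitrogen on the sulfonyl sulfur is therefore not needed for a low number, since a sulfonyl sulfur carrying only aromatic carbon does as well or better. No measurement available here accounts for the step.

On these data alone, whether the trifluoromethyl group contributes remains open, as plain phenyl and morpholin-4-yl do not appear at this position. Also open, as far as these compounds go, is whether the step carries over to the core of compound 1.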